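The compounds below may be only part of what the source reports. "The series", "measured", "known", "first", "only" and "open" are said of these compounds alone.

Series notes. Compound 1 `O=C(Nc1ccc(-n2ncc3c(Br)cccc32)cc1)Nc1ccc(Cl)c(C(F)(F)F)c1` gives 7700 nM in a functional assay on MDA-MB-231 cells (Homo sapiens) for cytotoxicity, read by MTT assay, with a stated time of 72 h; on this read-out higher numbers stand for weaker inhibition and lower numbers for stronger inhibition. Going by the values given here, compound 2 `Cc1cccc2c1cnn2-c1ccc(NC(=O)Nc2ccc(Cl)c(C(F)(F)F)c2)cc1` gives 2300 nM in this assay, and the single step in hand, a 3.3-fold lower number from compound 1 to compound 2 (0.52 log units; beyond the scatter), puts compound 2 at the lower of the two numbers measured so far, with compound 1 as its only neighbour.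

Compound 3 `O=C(Nc1ccc(-n2ncc3cnccc32)cc1)Nc1ccc(Cl)c(C(F)(F)F)c1` differs from compound 2 by a group of 9 heavy atoms (6 carbon, 3 nitrogen; one five-membered aromatic ring with 2 hetero atoms, one six-membered aromatic ring with 1 hetero atom) in place of a group of 10 heavy atoms (8 carbon, 2 nitrogen; one five-membered aromatic ring with 2 hetero atoms, one six-membered aromatic ring of carbon only), on an aromatic carbon; the 4-methyl-1H-indazol-1-yl group leaves and a bicycle of one five-membered aromatic ring with 2 hetero atoms and one six-membered aromatic ring with 1 hetero atom enters, on an aromatic carbon of a six-membered aromatic ring of carbon only, para to a large group. Among the compounds with values here, the one measured step, methyl in place of bromo on the same bicycle, was modest; it does not cover an exchange of the whole bicycle, so no measured step bears directly on this change. With the methyl gone, a step toward the number of compound 1 is expected rather than a gain, a 2.0-fold higher number from compound 2 to compound 3 (0.29 log units; within the scatter) in this assay, though within a wide range. Compound 3 is therefore estimated at 4500 nM in this assay, between 1500 nM and 14000 nM.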

Compound 3, half-maximal inhibitory concentration: 16000 nM
The estimate for compound 3 lay 3.6-fold (0.55 log units) below the measured number; measured number outside the range, above it.
By their numbers in this assay, from the lowest: compound 2; then compound 1; then compound 3.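

In this assay, the exchange of the whole bicycle at this place, on an aromatic carbon para to a large group, now has a measured size: a 7.0-fold higher number from compound 2 to compound 3 (0.84 log units; beyond the scatter) when the 4-methyl-1H-indazol-1-yl group leaves, and a 2.1-fold higher number from compound 1 to compound 3 (0.32 log units; beyond the scatter) when the bromo-bearing bicycle leaves. Both steps lie beyond the scatter, so compound 3 has the highest number of the three, and the entering bicycle, with a hetero atom in its six-membered ring and 3 hydrogen-bond acceptors against 2 for the 4-methyl-1H-indazol-1-yl group, matches neither of the two carbon-only six-membered rings shown here. No measurement at hand accounts for this loss, so the link between the result and the count of acceptors or the ring nitrogen remains only an observation.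

Compound 3 differs from compound 2 both in the ring nitrogen and in the absence of the methyl, and the three compounds cannot separate these two changes, which the 1H-indazol-1-yl group without any methyl or bromo would do. From the compounds shown here alone, whether a methyl or bromo on the nitrogen-containing bicycle, or a methoxy or an amine on either bicycle, would lower the number also stays open.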